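Moving the Hydroxyl Around on a Furan-Bearing Core

A few compounds are considered here, and "the series" means these few. Any claim that something is new, unique, unknown or untested is made for them only; others in the source may bear on it.

Compound 3 (`Oc1ccc(-c2cc(-c3ccoc3)cc(-c3ccccc3O)n2)cc1`) carries one 4-hydroxyphenyl group and one 2-hydroxyphenyl group on its shared core, together with a furan-3-yl group. In a functional assay on HCT-15 cells (Homo sapiens) for cytotoxicity, read by CCK-8 assay (a higher number here means a weaker inhibitor, a lower number a stronger inhibitor), compound 3 gives only the limit > 50000 nM. Compound 2 (`Oc1ccccc1-c1cc(-c2ccoc2)cc(-c2ccccc2O)n1`), which carries two 2-hydroxyphenyl groups, likewise gives only the limit > 50000 nM in this assay. Accordingly the step that the two limits leave unreadable from compound 2 to compound 3 cannot be sized, a consequence of the limit of > 50000 nM in this assay, at which 2 of the 3 values shown sit. Compound 1 (`Oc1ccc(-c2cc(-c3ccsc3)cc(-c3ccc(O)cc3)n2)cc1`), with two 4-hydroxyphenyl groups and a thiophen-3-yl group in place of the furan, gives 1040 nM in this assay.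

Compound 4 (`Oc1ccc(-c2cc(-c3ccoc3)cc(-c3ccc(O)cc3)n2)cc1`) differs from compound 3 by 4-hydroxyphenyl in place of 2-hydroxyphenyl on an aromatic carbon. Among the measured compounds shown here, the one measured step that makes the same exchange, a step that the two limits leave unreadable from compound 2 to compound 3, is unreadable because both of its compounds sit at the limit of > 50000 nM in this assay, at which 2 of the 3 values shown sit, so it offers no size to lean on. For the measured compounds named here, compound 1, which already holds two 4-hydroxyphenyl groups, is the only compound with a number, at 1040 nM. Compound 4 is therefore expected to move toward stronger inhibition, by a step of roughly an at least 12-fold lower number from compound 3 to compound 4 (1.09 log units; beyond the scatter). The estimate for compound 4 in this assay is 4000 nM, with a range from 800 nM to 30000 nM.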

Compound 4, half-maximal inhibitory concentration: 1530 nM
Estimate against measurement, compound 4: 2.6-fold (0.42 log units) above; the measured number falls inside the stated range.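

Exchanging 2-hydroxyphenyl for 4-hydroxyphenyl on the aromatic carbon next to the ring nitrogen now has a readable effect in this assay: the change gives an at least 32-fold lower number from compound 3 to compound 4 (1.51 log units; beyond the scatter), whereas the same exchange from compound 2 to compound 3 cannot be read. This size is a bound and not an exact figure, because compound 3 has only a limit and no measured number: the limit of > 50000 nM in this assay, at which 2 of the 4 values shown sit. With two 4-hydroxyphenyl groups on the shared core, furan-3-yl in place of thiophen-3-yl gives a 1.5-fold higher number from compound 1 to compound 4 (0.17 log units; within the scatter), so this exchange does not separate the two compounds in this assay.

The compounds shown leave open whether the hydroxyl itself is needed on the 4-hydroxyphenyl group, or whether a methoxy group or an amine at that spot on the ring would give a similar value. On these data alone, it also remains open whether thiophen-3-yl and furan-3-yl would still match on a core carrying a 2-hydroxyphenyl group, and whether a saturated ring or a short alkyl chain could take their place.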